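Amide substituent change from compound 3 to compound 4

The source may report more compounds than this note shows. Statements on the series, on what has been measured and on what is new or still open speak of the compounds shown alone.

Compound 1 `C=CC1=C(C(=O)Nc2ccccc2OC)C(c2ccc(Cl)c(Cl)c2)OC1` in a functional assay on QGY7701 cells (Homo sapiens) for cytotoxicity, read by MTT assay, with a stated time of 24 h (on this read-out lower numbers stand for stronger inhibition and higher numbers for weaker inhibition), gives > 100000 nM, a limit of the assay.
Compound 2 `C=CC1=C(C(=O)NC2CCCCC2)C(c2ccc(OC)cc2)OC1` in this assay gives > 100000 nM, also a limit.
Compound 3 `C=CC1=C(C(=O)NCc2ccccc2F)C(c2ccc(OC)cc2)OC1` in this assay gives > 100000 nM, again a limit.

Compound 3 therefore stands at the limit (the limit of > 100000 nM in this assay, at which 3 of the 3 values shown sit), and no measured value in this assay separates it from the others. Compound 4 `C=CC1=C(C(=O)Nc2ccccc2OC)C(c2ccc(OC)cc2)OC1` differs from it by 2-methoxyphenyl in place of 2-fluorobenzyl on an amide-type nitrogen, in words 2-methoxyphenyl in place of 2-fluorobenzyl on an amide-type nitrogen. For the measured compounds named here, the only measured step on this nitrogen, a step that the two limits leave unreadable from compound 2 to compound 3, is one the two limits leave unreadable, so no step of known size bears on the change. Compound 4 is accordingly expected to sit at or near the same limit in this assay, with an estimated value of 100000 nM and a range from 30000 nM to 300000 nM. The expected step of a number no higher from compound 3 to compound 4 (the limit leaves the size open) is thus none beyond the scatter.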

Compound 4, half-maximal inhibitory concentration: > 100000 nM
Compound 4: only a limit was reported; the forecaster's own chance of this, stated with the estimate: 85%; the middle value lies on the limit itself.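

Compound 4 joins compound 1, compound 2 and compound 3 at a limit, so no step among these compounds can be read: the limit of > 100000 nM in this assay, at which 4 of the 4 values shown sit. The compounds shown leave open whether any change on the amide-type nitrogen or the saturated ring carbon alters the read-out in this assay at all.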